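This account rests on a few compounds, and the source may have more. Where it says the series, first, only, none or still open, it means among the compounds named here.

Compound 1 `CC1=CCCC(C)(C)C1/C=C/C(=O)/C=C/c1ccccc1C(F)(F)F` gives 18400 nM in a functional assay on CWR22R cells (Homo sapiens) for cytotoxicity, read by MTT assay, with a stated time of 72 h; on this read-out higher numbers stand for weaker inhibition and lower numbers for stronger inhibition. Compound 2 `CC1=CCCC(C)(C)C1/C=C/C(=O)/C=C/c1ccccc1F` gives 9400 nM in this assay; the change is fluoro in place of trifluoromethyl on an aromatic carbon, and the step is a 2.0-fold lower number from compound 1 to compound 2 (0.29 log units; within the scatter). Compound 3 `CC1=C(/C=C/C(=O)/C=C/c2ccccc2C(F)(F)F)C(C)(C)CCC1O` gives 2300 nM in this assay, the lowest of the three numbers, with compound 2 nearest and compound 1 furthest; the difference between the core of compound 3 and the core of compound 1 is not broken down here. Compound 4 `CC1=C(/C=C/C(=O)/C=C/c2ccccc2F)C(C)(C)CCC1O` carries the same change on the core of compound 3: fluoro in place of trifluoromethyl on an aromatic carbon. The same change is expected to make a step of similar size on this second core, a 1.8-fold lower number from compound 3 to compound 4 (0.25 log units; within the scatter), because a 2.0-fold lower number from compound 1 to compound 2 (0.29 log units; within the scatter) stayed within the scatter. Compound 4 is therefore estimated at 1300 nM in this assay, expected to fall between 500 nM and 3500 nM.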

Compound 4, half-maximal inhibitory concentration: 3300 nM
Compound 4: the middle estimate sits 2.5-fold (0.40 log units) below what was measured, and the stated range covers the measured number.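

In this assay, fluoro in place of trifluoromethyl gives a 1.4-fold higher number from compound 3 to compound 4 (0.16 log units; within the scatter). Carried from one core to the other, the change does not keep its step: the same change on two cores in this assay, a 2.0-fold lower number (0.29 log units; within the scatter) from compound 1 to compound 2 and a 1.4-fold higher number (0.16 log units; within the scatter) from compound 3 to compound 4, 2.8-fold (0.45 log units) apart, beyond the scatter of two such steps. With one pair on each core, this shows that the step depends on the core for these four compounds, but it does not show which difference between the cores is responsible, and neither step alone lies beyond the scatter.

From the compounds shown here alone, it remains open whether a chloro or methoxy group on the same aromatic carbon would follow the step seen on either core. Also open, going by these compounds, is how an amine or a ketone in place of the hydroxyl on the core of compound 3 would read.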